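The source may report more compounds than this note shows. Statements on the series, on what has been measured and on what is new or still open speak of the compounds shown alone.

Measured compounds:
Compound 1, `CCCCCCc1c(F)c(N)c2c(=O)cc(-c3ccc(N)c(F)c3)oc2c1F`: in a functional assay on MCF7 cells (Homo sapiens) for cytotoxicity, read by neutral red uptake, with a stated time of 3 days (a lower number here means a stronger inhibitor, a higher number a weaker inhibitor), compound 1 gives only a limit, > 10000 nM.
Compound 2, `Nc1ccc(-c2cc(=O)c3c(N)c(F)c(CO)c(F)c3o2)cc1F`: in this assay compound 2 gives 62 nM.

Among the measured compounds shown here, compound 2 therefore stands alone as the only compound with a number in this assay; the other value shown is a limit (the limit of > 10000 nM in this assay, at which 1 of the 2 values shown sits), so no ranking between the two can be drawn beyond the one step that is known. That step, an at least 160-fold lower number from compound 1 to compound 2 (2.20 log units; beyond the scatter), is large and runs from the limit to the number of compound 2, but it concerns hydroxy in place of pentyl and not the change now at hand.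

Compound 3, `NCc1c(F)c(N)c2c(=O)cc(-c3ccc(N)c(F)c3)oc2c1F`, differs from compound 2 by amino in place of hydroxy on a saturated chain carbon bound to an aromatic carbon. For the measured compounds named here, no measured step shows an exchange of hydroxy for amino at this place, so the account rests on the fact that compound 2 already carries a small polar group there and that compound 3 keeps one. The writer therefore expects a step of a 1.3-fold higher number from compound 2 to compound 3 (0.11 log units; within the scatter), that is, no change beyond the scatter in this assay. For compound 3 the estimate in this assay is 80 nM, with a range from 20 nM to 400 nM.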

Compound 3, half-maximal inhibitory concentration: 26 nM
For compound 3 the middle estimate is 3.1-fold (0.49 log units) above the measured one; the measured number falls inside the stated range.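

In this assay, this place on a saturated chain carbon bound to an aromatic carbon distinguishes amino from hydroxy, even though the two groups have the same computed hydrogen-bond donor and acceptor counts and neither carries a net charge: a 2.4-fold lower number from compound 2 to compound 3 (0.38 log units; beyond the scatter). Measured against the pentyl-bearing compound, the amino group gives an at least 380-fold lower number from compound 1 to compound 3 (2.58 log units; beyond the scatter), so a second group at this place now stands far from compound 1 on the printed scale. Compound 1 gives only a limit, so this step marks a minimum size and not an exact one: the limit of > 10000 nM in this assay, at which 1 of the 3 values shown sits.

The compounds shown leave open whether the preference for aminomethyl over hydroxymethyl would extend to a methylamine, a dimethylamine, a carboxylic acid or a longer chain ending in an amine at this place. They also leave open whether the step between hydroxy and amino holds on cells other than those of this single assay, and what lies behind it, since the data here give a size for the step and no cause.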